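The compounds below may be only part of what the source reports. "The series", "measured", "known", "first", "only" and "open" are said of these compounds alone.

Measured so far:
compound 1 `COc1ccc([C@@H]2CC(=O)c3c(O)cc(OCc4cn(Cc5ccccc5C(F)(F)F)nn4)cc3O2)cc1O`, 12500 nM
compound 2 `COc1ccc([C@@H]2C/C(=N\O)c3c(O)cc(OCc4cn(C5CCCC5)nn4)cc3O2)cc1O`, 6880 nM

In a functional assay on RAW264.7 cells (Mus musculus) for inhibition, read by Griess assay, with stated times of 2 h and 24 h (on this read-out lower numbers stand for stronger inhibition and higher numbers for weaker inhibition), compound 1 gives 12500 nM. Going by the values given here, the only other measured compound, compound 2, gives 6880 nM in this assay; the gap between the two falls inside the usual scatter of repeated measurements, so compound 1 cannot be told apart from compound 2 on this read-out, and the series so far offers no step between measured compounds that differ in one place.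

The unmeasured compound 3 `CCCCn1cc(COc2cc(O)c3c(c2)O[C@H](c2ccc(OC)c(O)c2)CC3=O)nn1` keeps the core and the carbonyl of compound 1 and changes only the group on the triazole substituent: propyl in place of 2-(trifluoromethyl)phenyl on a saturated chain carbon bound to an aromatic nitrogen. Among the compounds with values here, since no measured pair shows this kind of change, there is no number to carry over. The expectation is a step of modest size, if any, in this assay from compound 1 to compound 3, in the direction of a somewhat higher number, but with a range that covers no change beyond the scatter; the step of a 1.3-fold higher number from compound 1 to compound 3 (0.11 log units; within the scatter) is the estimate. Compound 3 is thus expected to give 16000 nM in this assay, with a likely range from 6000 nM to 40000 nM.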

Compound 3, half-maximal inhibitory concentration: 13900 nM
The estimate for compound 3 lay 1.2-fold (0.06 log units) above the measured number; the range from low to high includes it.
By their numbers in this assay, from the lowest: compounds 2, 1 and 3 (each within the scatter of the next, the first and the last beyond it).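

Going by these compounds alone, on the triazole substituent, at a saturated chain carbon bound to an aromatic nitrogen, the first one-place comparison is now available: in this assay, propyl in place of 2-(trifluoromethyl)phenyl gives a 1.1-fold higher number from compound 1 to compound 3 (0.05 log units; within the scatter). At this position, a group of 10 heavy atoms with a six-membered aromatic ring of carbon only and a group of 3 heavy atoms with no ring therefore cannot be told apart on this read-out; read one bond further out, the same holds for 2-(trifluoromethyl)benzyl and butyl. No measurement shown offers an explanation for this result.

A single pair cannot show whether this position tolerates other kinds of group, such as a chain ending in an amine, a chain ending in a carboxylic acid, or a longer alkyl chain. The hydroxyimino group of compound 2 also remains unresolved, since compound 2 differs from compound 1 and compound 3 in more than one place and its contribution cannot be separated from that of its cyclopentyl group.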